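Aryl variation on the triazole nitrogen of the camphor-derived lactam

The source may report more compounds than this note shows. Statements on the series, on what has been measured and on what is new or still open speak of the compounds shown alone.

Of the compounds shown here, three have been measured in a functional assay on LoVo cells (Homo sapiens) for inhibition, read by MTT assay, with a stated time of 24 h; a lower number here means a stronger inhibitor, a higher number a weaker inhibitor. Compound 1 `CC1(C)[C@H]2CC[C@]1(C)N(Cc1cn(-c3ccccc3C#N)nn1)C(=O)C2` gives 140 nM. Compound 2 `CC1(C)[C@H]2CC[C@]1(C)N(Cc1cn(-c3ccc(F)cc3)nn1)C(=O)C2` gives 40 nM, and compound 3 `CC1(C)[C@H]2CC[C@]1(C)N(Cc1cn(-c3ccc(Cl)cc3)nn1)C(=O)C2` gives 160 nM. Among these three numbers compound 1 stands second highest; it sits close to compound 3 but clearly apart from compound 2. Among the compounds with values here, the steps so far are a 3.5-fold lower number from compound 1 to compound 2 (0.54 log units; beyond the scatter), a 1.1-fold higher number from compound 1 to compound 3 (0.06 log units; within the scatter) and a 4.0-fold higher number from compound 2 to compound 3 (0.60 log units; beyond the scatter).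

The next compound, compound 4 `COc1cccc(-n2cc(CN3C(=O)C[C@@H]4CC[C@@]3(C)C4(C)C)nn2)c1`, differs from compound 1 as follows: 3-methoxyphenyl in place of 2-cyanophenyl on an aromatic nitrogen. Within the data shown here, no measured step involves a 3-methoxyphenyl group, so nothing bears on it directly. The two steps from compound 1, to compound 2 and to compound 3, show that exchanging the 2-cyanophenyl for another aryl group has so far moved this assay by a modest amount at most, in either direction or not beyond the scatter. On that basis the step of a 1.2-fold lower number from compound 1 to compound 4 (0.07 log units; within the scatter) is expected to be small. Compound 4 is therefore estimated at 120 nM, with a range from 40 nM to 350 nM.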

Compound 4, half-maximal inhibitory concentration: 80 nM
Compound 4: the middle estimate sits 1.5-fold (0.18 log units) above what was measured; the range from low to high includes it.
By their numbers in this assay, from the lowest: compounds 2, 4, 1 and 3 (each within the scatter of the next, the first and the last beyond it).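

In this assay, the 3-methoxyphenyl group on the aromatic nitrogen leaves compound 4 within the scatter of all three earlier compounds, with a 1.8-fold lower number from compound 1 to compound 4 (0.24 log units; within the scatter) and a 2.0-fold lower number from compound 3 to compound 4 (0.30 log units; within the scatter) and a 2.0-fold higher number from compound 2 to compound 4 (0.30 log units; within the scatter) as its steps. Compound 4 therefore cannot be separated from either compound 2 or compound 3, although those two lie beyond the scatter of each other, so this aryl change gives no ranking against any of the other three compounds. No measurement shown here explains these values.

As far as these compounds go, it remains open whether the values stay in this narrow span with a carboxylic acid or an aminomethyl group on the phenyl ring. From the compounds shown here alone, a cyclohexyl or benzyl group in place of the aryl ring on the triazole nitrogen is equally open.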